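The source may report more compounds than this note shows. Statements on the series, on what has been measured and on what is new or still open speak of the compounds shown alone.

Compound 1 `CCC1=C(O)c2c(oc(-c3cccc(C)c3)cc2=O)C(CC)(CC)C1=O` and compound 2 `CCC1=C(O)c2c(oc(-c3ccc(C)c(C)c3)cc2=O)C(CC)(CC)C1=O` share one core and differ in a single place. In a functional assay on KB cells (Homo sapiens) for antiproliferative activity, read by sulforhodamine B assay, with a stated time of 3 days (on this read-out lower numbers stand for an effect already at smaller amounts and higher numbers for an effect only at larger amounts of compound), compound 1 gives 49.7 uM and compound 2 gives 35.5 uM. For the measured compounds named here, the step of a 1.4-fold lower number from compound 1 to compound 2 (0.15 log units; within the scatter) is the only measured step in the set. Going by the values given here, compound 2 thus holds the lower of the two numbers, but its sole neighbour, compound 1, sits within the scatter, so no order between the two can be claimed.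

Compound 3 `CCC1=C(O)c2c(oc(-c3ccc(F)c(C)c3)cc2=O)C(CC)(CC)C1=O` is the next member to be measured. Its difference from compound 2: fluoro in place of methyl on an aromatic carbon. Among the compounds with values here, no measured pair covers a fluoro entering in place of a methyl; the one step on hand, a 1.4-fold lower number from compound 1 to compound 2 (0.15 log units; within the scatter), concerns a methyl entering for hydrogen and stayed within the scatter. That step bears only loosely on the present change, and it gives no reason to expect a movement beyond the scatter in this assay in either direction. The estimate for compound 3 in this assay is therefore 35 uM, with a range from 15 uM to 80 uM, meaning an expected step of a 1.0-fold lower number from compound 2 to compound 3 (0.01 log units; within the scatter).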

Compound 3, concentration for half-maximal effect: 40.5 uM
Compound 3: middle estimate off by 1.2-fold (0.06 log units), on the low side; measured number inside the range.
By their numbers in this assay, from the lowest: compounds 2, 3 and 1 (each within the scatter of the next).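

In this assay, for the compounds shown here, going from the 3,4-dimethylphenyl to the 4-fluoro-3-methylphenyl gives a first reading of a swap between two substituents at this position (a 1.1-fold higher number from compound 2 to compound 3 (0.06 log units; within the scatter)), and the same fluoro can also be read against hydrogen (a 1.2-fold lower number from compound 1 to compound 3 (0.09 log units; within the scatter)). The aromatic carbon ortho to a methyl group and para to a large group has now carried hydrogen, methyl and fluoro, and the three compounds stay within the scatter of one another, so no order among these three substituents can be stated. Nothing on hand gives any account of how these numbers arise.

Going by these compounds, it remains open whether a larger or charged group at this carbon, such as a methoxy, an amine or a carboxylic acid, would move the number beyond the scatter. The compounds shown also say nothing about the ethyl groups on the shared core or about the methyl group that all three compounds keep on the aromatic ring, so it is unknown whether changes there would shift the number in this assay more than the changes seen so far.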